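A few compounds are considered here, and "the series" means these few. Any claim that something is new, unique, unknown or untested is made for them only; others in the source may bear on it.

Measured compounds in a functional assay on QG-56 cells (Homo sapiens) for antiproliferative activity; a lower number here means a stronger inhibitor, a higher number a weaker inhibitor:
- Compound 1, `Cn1cncc1C(O)(c1ccc(C#N)cc1)c1cc2cc([N+](=O)[O-])cc(-c3cccc(C#N)c3)c2o1`, gives 22.9 nM.
- Compound 2, `COc1cccc(-c2cc([N+](=O)[O-])cc3cc([C@](N)(c4ccc(C#N)cc4)c4cncn4C)oc23)c1`, gives 1.1 nM.
- Compound 3, `Cn1cncc1[C@](N)(c1ccc(C#N)cc1)c1cc2cc([N+](=O)[O-])cc(-c3ccccc3)c2o1`, gives 206 nM.

Among these three numbers compound 1 stands second highest: compound 3 lies at a higher number, beyond the scatter, while compound 2 lies at a lower number, also beyond the scatter. The account now follows the step from compound 1 to compound 4, `Cc1cccc(-c2cc([N+](=O)[O-])cc3cc(C(O)(c4ccc(C#N)cc4)c4cncn4C)oc23)c1`. The change is methyl in place of cyano on an aromatic carbon. Among the measured compounds shown here, no measured pair in this set shows that same exchange, so its size is not known from the data. A small step is expected, towards a lower number or none beyond the scatter, as a 1.5-fold lower number from compound 1 to compound 4 (0.18 log units; within the scatter). Compound 4 is therefore estimated at 15 nM, with a range from 4 nM to 60 nM.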

Compound 4, half-maximal inhibitory concentration: 23.2 nM
The estimate for compound 4 lay 1.5-fold (0.19 log units) below the measured number, within the range that was stated.
By their numbers in this assay, from the lowest: compound 2; then compounds 1 and 4 (each within the scatter of the next); then compound 3.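

In this assay, among the compounds shown here, the exchange of 3-cyanophenyl for 3-methylphenyl gives a 1.0-fold higher number from compound 1 to compound 4 (0.01 log units; within the scatter) and is the first comparison in this set that differs in one place only. At this aromatic carbon, this read-out does not separate the cyano group from the methyl group, even though only the cyano group counts a hydrogen-bond acceptor. No measured evidence here bears on this result. Still open, from the compounds shown here alone, is how an amine or a carboxylic acid would read at this position, and whether the same exchange gives the same result in another compound.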